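The source may report more compounds than this note shows. Statements on the series, on what has been measured and on what is new or still open speak of the compounds shown alone.

Measured in a functional assay on A2780cisR cells (Homo sapiens) for cytotoxicity, read by MTT assay, with a stated time of 72 h; a higher number here means a weaker inhibitor, a lower number a stronger inhibitor:
- compound 1 `CN(C)c1ccc(C(=O)N(CCCCCC(=O)NO)CC(=O)NC2CCCCC2)cc1`: 3310 nM
- compound 2 `CC(C)(C)NC(=O)CN(CCCCCC(=O)NO)C(=O)c1ccccc1`: 42400 nM

Compound 2 has the higher number of the two, a gap to compound 1 beyond the scatter. Compound 3 `CN(C)c1ccc(C(=O)N(CCCCCC(=O)NO)CC(=O)NC(C)(C)C)cc1` differs from compound 2 by one change: dimethylamino in place of hydrogen on an aromatic carbon. For the measured compounds named here, no measured step isolates this change. Compound 1, at 3310 nM, carries the same dimethylamino group but also has a different amide substituent, so only a partial move towards it is expected. The expected step in this assay is a 5.3-fold lower number from compound 2 to compound 3 (0.72 log units; beyond the scatter), a fall beyond the scatter. The estimate for compound 3 is 8000 nM, with a range of 2500 nM to 25000 nM.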

Compound 3, half-maximal inhibitory concentration: 5180 nM
For compound 3 the middle estimate is 1.5-fold (0.19 log units) above the measured one; measured number inside the range.
By their numbers in this assay, from the lowest: compounds 1 and 3 (each within the scatter of the next); then compound 2.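

In this assay the aromatic carbon para to a large group proves sensitive: dimethylamino in place of hydrogen gives an 8.2-fold lower number from compound 2 to compound 3 (0.91 log units; beyond the scatter) on the tert-butyl amide. With dimethylamino in place, tert-butyl in place of cyclohexyl on the amide nitrogen gives a 1.6-fold higher number from compound 1 to compound 3 (0.19 log units; within the scatter) and so stays within the scatter. No measurement bearing on the reason for the dimethylamino step is available.

From the compounds shown here alone, whether a primary amine or a methoxy group at this position would give a similar step remains open. So does whether cyclohexyl and tert-butyl also match on the unsubstituted phenyl.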